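A few compounds are considered here, and "the series" means these few. Any claim that something is new, unique, unknown or untested is made for them only; others in the source may bear on it.

Compound 1 `COc1cc(/C=C/C(=O)/C=C(O)/C=C/c2ccc(OC(C)(C)C(=O)Nc3ccc([N+](=O)[O-])c(C(F)(F)F)c3)c(OC)c2)ccc1O` in a functional assay on PC-3 cells (Homo sapiens) for cytotoxicity, read by sulforhodamine B assay, with a stated time of 72 h (a lower number here means a stronger inhibitor, a higher number a weaker inhibitor), gives > 100000 nM, which is a limit of the assay rather than a number.
Compound 2 `COc1cc(/C=C/C(=O)/C=C(O)/C=C/c2ccc(OC(C)(C)C(=O)Nc3ccc(C#N)c(C(F)(F)F)c3)c(OC)c2)ccc1O` in this assay gives 48100 nM.
Compound 3 `COc1ccc(/C=C/C(=O)/C=C(O)/C=C/c2ccc(OCC(C)(O)C(=O)Nc3ccc([N+](=O)[O-])c(C(F)(F)F)c3)c(OC)c2)cc1OC` in this assay gives 39100 nM.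

Compound 4 `COc1ccc(/C=C/C(=O)/C=C(O)/C=C/c2ccc(OCC(C)(O)C(=O)Nc3ccc(C#N)c(C(F)(F)F)c3)c(OC)c2)cc1OC` has not yet been measured. It differs from compound 3 by cyano in place of nitro on an aromatic carbon. The same change, (cyano in place of nitro on an aromatic carbon), turned compound 1 into compound 2, and in this assay that gave an at least 2.0-fold lower number from compound 1 to compound 2 (0.31 log units; beyond the scatter). Because compound 1 sits at the limit of > 100000 nM in this assay, at which 1 of the 3 values shown sits, the true size of that step is open above. How the core of compound 3 differs from the core of compound 1 is not broken down here. Compound 3 and compound 2 give values that lie within the scatter of each other. The step expected from compound 3 to compound 4 is a 2.0-fold lower number from compound 3 to compound 4 (0.29 log units; within the scatter), resting on an at least 2.0-fold lower number from compound 1 to compound 2 (0.31 log units; beyond the scatter). Compound 4 is therefore estimated at 20000 nM, between 8000 nM and 45000 nM.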

Compound 4, half-maximal inhibitory concentration: 100000 nM
Estimate against measurement, compound 4: 5.0-fold (0.70 log units) below, and the stated range ends below it.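

In this assay, putting cyano in place of nitro gives a 2.6-fold higher number from compound 3 to compound 4 (0.41 log units; beyond the scatter), so the change does not carry over from one core to the other in the same direction: the same change on two cores in this assay, an at least 2.0-fold lower number (0.31 log units; beyond the scatter) from compound 1 to compound 2 and a 2.6-fold higher number (0.41 log units; beyond the scatter) from compound 3 to compound 4, at least 5.3-fold (0.72 log units) apart, beyond the scatter of two such steps

Compound 1 stands at a limit of the assay and not at a number, which leaves the size of the earlier step open: the limit of > 100000 nM in this assay, at which 1 of the 4 values shown sits.

Among these compounds, with only one pair on each core, and the cores not broken down into single changes, this does not show which part of the core goes with the reversal.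

Still open, as far as these compounds go, is how an amine or a carboxylic acid on the same aromatic carbon would behave on either core. Also open, from the compounds shown here alone, is whether the reversal would appear on a core that differs from the core of compound 1 in one place only.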